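Swapping Thiophen-2-yl for Phenyl: Expected Cytotoxicity of Compound 4

The compounds below may be only part of what the source reports. "The series", "measured", "known", "first", "only" and "open" are said of these compounds alone.

Measured compounds:
Compound 1 `Oc1ccc(-c2cc(-c3cccc(Cl)c3)nc(-c3ccccn3)c2)cc1`: 28200 nM
Compound 2 `Oc1ccc(-c2cc(-c3ccccc3)nc(-c3ccccc3Cl)c2)cc1`: 4990 nM
Compound 3 `Oc1ccc(-c2cc(-c3cccc(Cl)c3)nc(-c3cccs3)c2)cc1`: 5050 nM

In a functional assay on HCT-15 cells (Homo sapiens) for cytotoxicity, read by CCK-8 assay and cell counting, with a stated time of 2 days (a lower number here means a stronger inhibitor, a higher number a weaker inhibitor), compound 3 stands second highest of the three numbers; compound 2 sits within the scatter of it, while compound 1 lies well above it, as the step of a 5.6-fold lower number from compound 1 to compound 3 (0.75 log units; beyond the scatter) shows. Compound 4 `Oc1ccc(-c2cc(-c3ccccc3)nc(-c3cccc(Cl)c3)c2)cc1` differs from compound 3 in one place: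

phenyl in place of thiophen-2-yl on an aromatic carbon

Going by the values given here, no measured step covers this exchange. The only step shown, a 5.6-fold lower number from compound 1 to compound 3 (0.75 log units; beyond the scatter), concerns a different change at the same position and does not carry over. Compound 2, which also bears a phenyl at this position, gives 4990 nM, close to compound 3. Compound 4 is therefore expected to show no step beyond the scatter, an estimated 1.1-fold lower number from compound 3 to compound 4 (0.05 log units; within the scatter), with an estimate of 4500 nM and a range of 1500 nM to 13000 nM in this assay.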

Compound 4, half-maximal inhibitory concentration: 6100 nM
Compound 4: the middle estimate sits 1.4-fold (0.13 log units) below what was measured; measured number inside the range.
By their numbers in this assay, from the lowest: compounds 2, 3 and 4 (each within the scatter of the next); then compound 1.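

In this assay, phenyl and thiophen-2-yl on the aromatic carbon next to the ring nitrogen cannot be told apart, with a 1.2-fold higher number from compound 3 to compound 4 (0.08 log units; within the scatter). The 3-chlorophenyl and 2-chlorophenyl groups likewise cannot be separated, with a 1.2-fold higher number from compound 2 to compound 4 (0.09 log units; within the scatter). Pyridin-2-yl stands apart from phenyl, with a 4.6-fold lower number from compound 1 to compound 4 (0.66 log units; beyond the scatter), as it does from thiophen-2-yl. Going by these compounds, whether an amine or a carboxylic acid at this position would read like phenyl or like pyridin-2-yl remains open. Nothing available explains why pyridin-2-yl stands apart.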